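Para substituent swap on the aryl piperazine pyrazine amide

A few compounds are considered here, and "the series" means these few. Any claim that something is new, unique, unknown or untested is made for them only; others in the source may bear on it.

Compound 1 `O=C(NCN1CCN(c2ccc(Cl)cc2)CC1)c1cnccn1` and compound 2 `O=C(NCN1CCN(c2ccc(F)cc2)CC1)c1cnccn1` share one core, and compound 3 `O=C(NCN1CCN(c2ccc(C(F)(F)F)cc2)CC1)c1cnccn1` is the next member of the set. In a functional assay on Vero cells (Chlorocebus sabaeus) for cytotoxicity, read by MTT assay (on this read-out lower numbers stand for higher toxicity in this test and higher numbers for lower toxicity in this test), compound 1 gives "not determined" (no result reported). For compound 2 this assay reports a limit only, > 62.5 ug/mL. That is where compound 2 stands: the limit of > 62.5 ug/mL in this assay, at which 1 of the 2 values shown sits, so no single toxicity number is fixed for it. Compound 3 differs from compound 2 by trifluoromethyl in place of fluoro on an aromatic carbon. For the measured compounds named here, no measured step exists to lean on, and the step that the limit leaves unreadable from compound 2 to compound 3 is expected to stay within the scatter. Compound 3 is expected to give 70 ug/mL, with a range from 25 ug/mL to 200 ug/mL, most likely again reported as a limit.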

Compound 3, half-maximal cytotoxic concentration: > 62.5 ug/mL
Compound 3: a limit, no number; the forecaster's own chance of this, stated with the estimate: 60%; the middle value is on the limit's open side.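

No step can be read from compound 2 to compound 3, since both results in this assay are limits: the limit of > 62.5 ug/mL in this assay, at which 2 of the 3 values shown sit. Still open, going by these compounds, is whether trifluoromethyl in place of fluoro changes toxicity in this assay at all, and what single toxicity number either compound would have.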